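The source may report more compounds than this note shows. Statements on the series, on what has been measured and on what is new or still open speak of the compounds shown alone.

The shared core carries an amide that joins a quinolinone bearing an aryl group on its nitrogen to an aniline linked through an ether to a bicyclic heteroaromatic. Compound 1 `O=C(Nc1ccc(Oc2ccnc3[nH]ccc23)cc1)c1cn(-c2ccc(F)cc2)c2ccccc2c1=O` has a 4-fluorophenyl on the quinolinone nitrogen and no fluorine on the aniline. In a functional assay on MCF7 cells (Homo sapiens) for inhibition, read by MTT assay, with a stated time of 72 h (a lower number here means a stronger inhibitor, a higher number a weaker inhibitor), compound 1 gives 720 nM. Compound 2 `Cn1ccc2c(Oc3ccc(NC(=O)c4cn(-c5ccc(F)cc5)c5ccccc5c4=O)cc3F)ccnc21` carries a methyl on the heteroaromatic nitrogen, and in this assay compound 2 gives "not determined" (no result reported), so no number is available for it. Compound 3 `O=C(Nc1ccc(Oc2ccnc3[nH]ccc23)c(F)c1)c1cn(-c2ccccc2)c2ccccc2c1=O` has a plain phenyl on the quinolinone nitrogen and a fluorine on the aniline ring, and in this assay compound 3 gives 430 nM. The numbers for compound 3 and compound 1 lie within the usual scatter of each other, so neither can be called the stronger one.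

Compound 4 `O=C(Nc1ccc(Oc2ccnc3[nH]ccc23)c(F)c1)c1cn(-c2ccc(F)cc2)c2ccccc2c1=O` combines both fluorines. It differs from compound 3 by fluoro in place of hydrogen on an aromatic carbon. Compound 1 already carries this 4-fluorophenyl and sits close to compound 3 in this assay, so no step beyond the scatter is expected. The step from compound 3 to compound 4 is estimated as a 1.0-fold higher number from compound 3 to compound 4 (0.02 log units; within the scatter), and compound 4 is expected to give about 450 nM, with a plausible range from 200 nM to 1000 nM.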

Compound 4, half-maximal inhibitory concentration: 520 nM
Estimate against measurement, compound 4: 1.2-fold (0.06 log units) below; measured number inside the range.
By their numbers in this assay, from the lowest: compounds 3, 4 and 1 (each within the scatter of the next).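

Replacing phenyl with 4-fluorophenyl on the quinolinone nitrogen gives a 1.2-fold higher number from compound 3 to compound 4 (0.08 log units; within the scatter) in this assay, so with the aniline fluorine present, this change at the carbon para to a large group makes no readable difference. Compound 1 and compound 4 differ only by the fluorine on the aniline ring, and that change gives a 1.4-fold lower number from compound 1 to compound 4 (0.14 log units; within the scatter) with the 4-fluorophenyl present, so it too makes no readable difference. Together the two steps show that neither single fluorine separates these compounds in this cell assay, although the earlier compounds differed in two places and could not show this. No measurement available here offers an explanation for these results.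

On these data alone, compound 2 has no reported number, so the steps involving it cannot be read, and the effect of the methyl on the heteroaromatic nitrogen stays unknown. As far as these compounds go, it also remains open whether a larger or differently built group at this position of the phenyl ring, such as a methoxy group, an amine or a carboxylic acid, would move the number beyond the scatter.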